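From methoxy to hydroxy: the expected step to compound 3

This account rests on a few compounds, and the source may have more. Where it says the series, first, only, none or still open, it means among the compounds named here.

Measured in a functional assay on PC-3 cells (Homo sapiens) for cytotoxicity, read by MTT assay, with a stated time of 48 h (a lower number here means a stronger inhibitor, a higher number a weaker inhibitor), so far:
- compound 1 `CCC/C=C/[C@@H]1OC(=O)c2cc(O)cc(O)c2[C@@H]1O` gives > 50000 nM (a limit of the assay, not a number)
- compound 2 `CCC[C@@H]1C[C@H](O)[C@@H](OC)/C=C/C=C\C(=O)O1` gives 22000 nM

Going by the values given here, compound 2 holds the only actual number in this assay so far, at 22000 nM. Compound 1 is reported only as a limit, > 50000 nM. The next compound to be read is compound 3 `CCC[C@@H]1C[C@H](O)[C@@H](O)/C=C/C=C\C(=O)O1`, which differs from compound 2 by a single change (hydrogen in place of methyl on an oxygen on a saturated carbon). This change puts hydrogen in place of methyl on an oxygen on a saturated carbon, so that methoxy becomes hydroxy.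

Among the compounds with values here, no measured pair shows what such a change does, so the expectation rests on compound 2 alone. No step beyond the usual scatter is expected in this assay, with a slight lean towards weaker inhibition. A result reported only as a limit remains possible. The expected change is a 1.4-fold higher number from compound 2 to compound 3 (0.13 log units; within the scatter). For compound 3 the estimated value is 30000 nM, with an expected range from 10000 nM to 70000 nM.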

Compound 3, half-maximal inhibitory concentration: 18000 nM
The estimate for compound 3 lay 1.7-fold (0.22 log units) above the measured number; low and high end bracket the measured number.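

In this assay, the series now has its first pair of compounds differing in one place, and placing hydrogen instead of methyl on the oxygen on a saturated carbon gives a 1.2-fold lower number from compound 2 to compound 3 (0.09 log units; within the scatter). At this position, methoxy and hydroxy therefore cannot be told apart in this assay, and the methyl group shows no measurable contribution to the read-out. The pair does not place either compound ahead of the other, and the only other result available for comparison is a limit of the assay, held by compound 1, not a number: the limit of > 50000 nM in this assay, at which 1 of the 3 values shown sits.

The compounds shown leave open whether anything on this oxygen can move the number beyond the scatter, for instance a longer chain in place of methyl, or a carboxylic acid or an amine carried on such a chain. They also leave open whether the same exchange behaves alike on a different core or in other cells, since one pair in this assay is the whole record of this change.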